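Ortho chloro on the benzyl arm of compound 3

This account rests on a few compounds, and the source may have more. Where it says the series, first, only, none or still open, it means among the compounds named here.

Of the compounds shown here, three sharing one core have been measured in a functional assay on the whole organism (artery, strain albino) with Rattus norvegicus as the target, with a stated time of 120 min, at a dose of 10 mg/kg by the oral route; a higher number here means more inhibition at the dose given (going by the name of the read-out), a lower number less inhibition. Compound 1 `CC1=C(C(=O)Nc2ccc([N+](=O)[O-])cc2)C(c2ccc(Br)cc2)N=C(SCc2ccccc2)N1` gives 13.4%. Compound 2 `CC1=C(C(=O)Nc2ccc([N+](=O)[O-])cc2)C(c2ccc(Br)cc2)N=C(SCc2ccccc2Cl)N1` gives 7.7%, and compound 3 `CC1=C(C(=O)Nc2ccc([N+](=O)[O-])cc2)C(c2cccc([N+](=O)[O-])c2)N=C(SCc2ccccc2)N1` gives 10.3%. All three numbers lie within the usual scatter of one another, so compound 3 cannot be set apart from either neighbour: the step of a number 3.1 percentage points lower from compound 1 to compound 3 (within the scatter) is a change that repeated testing could produce by itself.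

Compound 4 `CC1=C(C(=O)Nc2ccc([N+](=O)[O-])cc2)C(c2cccc([N+](=O)[O-])c2)N=C(SCc2ccccc2Cl)N1` differs from compound 3 in one place: chloro in place of hydrogen on an aromatic carbon. The same change has been made once before, from compound 1 to compound 2, where it gave a number 5.7 percentage points lower from compound 1 to compound 2 (within the scatter). Within the data shown here, that single step is the only direct guide, and it stayed inside the scatter. The expectation for compound 4 is therefore a small downward movement, if any, as a number 4.3 percentage points lower from compound 3 to compound 4 (within the scatter), with the true result just as likely to sit at the same level as compound 3.

Compound 4 is estimated at 6%, within a range from 0% to 15%, in this assay.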

Compound 4, a percentage reported as inhibition, in the whole organism at one dose (the size of the read-out at that dose, not a potency): 7.7%
Compound 4: the middle estimate sits 1.7 percentage points below what was measured; measured number inside the range.
By their numbers in this assay, from the lowest: compounds 2, 4, 3 and 1 (each within the scatter of the next).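

Chloro in place of hydrogen on this aromatic carbon of the benzyl arm can now be read on a second core in this assay and the new reading is a number 2.6 percentage points lower from compound 3 to compound 4 (within the scatter). Set beside the earlier step, this shows that the change reads alike on both cores as far as this assay can tell: the same change on two cores in this assay, a number 5.7 percentage points lower (within the scatter) from compound 1 to compound 2 and a number 2.6 percentage points lower (within the scatter) from compound 3 to compound 4, 3.1 percentage points apart, within the scatter of two such steps. The swap to 3-nitrophenyl from 4-bromophenyl also gains a second reading, now with the chloro present, as no change at the digits printed from compound 2 to compound 4 (within the scatter), and it too agrees with its earlier step: the same change on two cores in this assay, a number 3.1 percentage points lower (within the scatter) from compound 1 to compound 3 and no change at the digits printed (within the scatter) from compound 2 to compound 4, 3.1 percentage points apart, within the scatter of two such steps.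

On these data alone, every step here stays inside the scatter, so it remains open whether any group at this position can move the number clearly. An amine or a carboxylic acid in place of the chloro would test that, and a single dose gives no potency for any of these compounds.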